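Extending the unsaturated amide chain on a shared core

The source may hold more compounds than are shown below. What is called first, only, known or untested is meant among the compounds shown, and "the series" means these compounds.

Compound 1 `C=CC(=O)Nc1cc2c(N3CCc4ccccc43)ncnc2cc1OC` and compound 2 `C=C(C)C(=O)Nc1cc2c(N3CCc4ccccc43)ncnc2cc1OC` share one core and differ only in their unsaturated amide. In a functional assay on PC-3 cells (Homo sapiens) for antiproliferative activity, read by MTT assay, with a stated time of 72 h (on this read-out lower numbers stand for stronger inhibition and higher numbers for weaker inhibition), compound 1 gives 5940 nM, and compound 2 gives 4830 nM, the lowest of the two numbers, with a 1.2-fold lower number from compound 1 to compound 2 (0.09 log units; within the scatter). Compound 3 `COc1cc2ncnc(N3CCc4ccccc43)c2cc1NC(=O)C=C(C)C` carries a further change: 2-methylprop-1-en-1-yl in place of 1-methylethenyl on a carbonyl carbon. Within the data shown here, the only measured step that bears on this chain, from compound 1 to compound 2, stayed within the scatter, so compound 3 is expected to show a 1.3-fold higher number from compound 2 to compound 3 (0.13 log units; within the scatter), no clear shift in either direction. Compound 3 is therefore estimated at 6500 nM, between 2500 nM and 17000 nM.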

Compound 3, half-maximal inhibitory concentration: 7840 nM
Compound 3: the middle estimate sits 1.2-fold (0.08 log units) below what was measured, within the range that was stated.
By their numbers in this assay, from the lowest: compounds 2, 1 and 3 (each within the scatter of the next).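

Putting 2-methylprop-1-en-1-yl on the carbonyl carbon gives a 1.6-fold higher number from compound 2 to compound 3 (0.21 log units; within the scatter) and, set against vinyl, a 1.3-fold higher number from compound 1 to compound 3 (0.12 log units; within the scatter) in this assay. Even this larger chain therefore leaves the number within the scatter of both smaller ones, so the three unsaturated chains shown cannot be told apart in this assay. No measured data are available to explain this result.

As far as these compounds go, whether a longer chain, or a chain carrying an amine, on this carbonyl carbon would move the number beyond the scatter stays open.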